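Ring contraction of the basic amine on the propoxy chain

A few compounds are considered here, and "the series" means these few. Any claim that something is new, unique, unknown or untested is made for them only; others in the source may bear on it.

In a physicochemical assay for lipophilicity, using the shake flask method, measured as octanol-water partition, at pH 7.4 (a lower number here means a more polar compound, a higher number a more lipophilic compound), compound 2 `COc1cc(/C=C/C(=O)Nc2ccccc2)ccc1OCCCN1CCCCC1` gives 1.58, and compound 1 `COc1cc(/C=C/C(=O)Nc2ccccc2)ccc1OCCCN(C)C` gives 1.55 in this assay, the two numbers lying within the scatter of each other. Compound 3 `COc1cc(/C=C/C(=O)Nc2ccccc2)ccc1OCCCN1CCCC1` differs from compound 2 by pyrrolidin-1-yl in place of piperidin-1-yl on a saturated chain carbon, three bonds along the chain from an oxygen on an aromatic ring. Going by the values given here, the one measured step that bears on this is a number 0.03 log units higher from compound 1 to compound 2 (within the scatter), a change at the same amine that left this assay flat. For compound 3 a small downward step is therefore expected, a number 0.13 log units lower from compound 2 to compound 3 (within the scatter), probably within the scatter. Compound 3 is estimated at 1.45, with a range of 1.15 to 1.75.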

Compound 3, partition coefficient: 1.57
Estimate against measurement, compound 3: 0.12 log units below; the range from low to high includes it.
By their numbers in this assay, from the lowest: compounds 1, 3 and 2 (each within the scatter of the next).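

In this assay, the change to pyrrolidin-1-yl on this chain gives a number 0.01 log units lower from compound 2 to compound 3 (within the scatter) and, set against dimethylamino, a number 0.02 log units higher from compound 1 to compound 3 (within the scatter). Compound 1, compound 2 and compound 3 thus all lie within the scatter of each other, and the five-membered and six-membered rings are not told apart at this position. Nothing on hand accounts for this flat reading.

As far as these compounds go, whether morpholin-4-yl on the same chain, or a longer chain carrying piperidin-1-yl, would leave this assay equally flat remains open.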